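A few compounds are considered here, and "the series" means these few. Any claim that something is new, unique, unknown or untested is made for them only; others in the source may bear on it.

Working notes on the series, read in a functional assay on WM 266-4 cells (Homo sapiens) for antiproliferative activity, read by MTT assay, with a stated time of 24 h; a lower number here means a stronger inhibitor of growth, a higher number a weaker inhibitor of growth. Compound 1 `c1ccc(N2N=C(c3ccc4c(c3)OCCO4)CC2c2ccco2)cc1` gives > 100000 nM, which is a limit of the assay and not a number. Compound 2 `FC(F)(F)c1ccc(C2CC(c3ccc4c(c3)OCCO4)=NN2c2ccccc2)cc1` gives > 100000 nM, which is likewise a limit. Within the data shown here, compound 3 `Brc1ccc(C2CC(c3ccc4c(c3)OCCO4)=NN2c2ccccc2)cc1` gives 3010 nM, the only true number so far and the strongest result of the three, set against (the limit of > 100000 nM in this assay, at which 2 of the 3 values shown sit).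

Compound 4 `c1ccc(N2N=C(c3ccc4c(c3)OCCO4)CC2c2cccc3ccccc23)cc1` differs from compound 3 at one place: naphthalen-1-yl in place of 4-bromophenyl on a saturated ring carbon. In words, naphthalen-1-yl stands in place of 4-bromophenyl on a saturated ring carbon.

Among the measured compounds shown here, two measured steps bear on this change. At the same carbon, the data show an at least 33-fold lower number from compound 1 to compound 3 (1.52 log units; beyond the scatter), and they also show a step that the two limits leave unreadable from compound 1 to compound 2. Within the group that leaves, the data show an at least 33-fold lower number from compound 2 to compound 3 (1.52 log units; beyond the scatter). Both readable steps are large and end at compound 3, so in these three compounds the read-out is sensitive to the group at this place. None of them tests naphthalen-1-yl directly. Removing the 4-bromophenyl of compound 3 is therefore expected to weaken growth inhibition, and a result at the limit remains possible. The expected change is a 4.0-fold higher number from compound 3 to compound 4 (0.60 log units; beyond the scatter), towards a higher number. In this assay the estimate for compound 4 is 12000 nM, with an expected range of 1500 nM to 80000 nM.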

Compound 4, concentration for 50% growth inhibition: > 100000 nM
Compound 4 gave a limit, no number (the forecaster's own chance of this, stated with the estimate: 35%); middle value at least 8.3-fold (0.92 log units) from the limit.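

The change to naphthalen-1-yl gives an at least 33-fold higher number from compound 3 to compound 4 (1.52 log units; beyond the scatter), so a second carbon-only aromatic ring at this saturated ring carbon does not keep the growth inhibition seen with 4-bromophenyl. In this assay compound 4 gives > 100000 nM, which is a limit and not a number. Furan-2-yl, 4-(trifluoromethyl)phenyl and now naphthalen-1-yl all end at the limit, leaving the 4-bromophenyl of compound 3 as the only group here with a true number, and the steps among compound 1, compound 2 and compound 4 cannot be read, so these three groups cannot be ranked against each other: the limit of > 100000 nM in this assay, at which 3 of the 4 values shown sit.

The compounds shown leave open whether the number of compound 3 depends on the bromine itself, since only one halogen appears at this place, and 4-chlorophenyl, 4-iodophenyl or unsubstituted phenyl at the same carbon would bear on that. They also leave open how a 4-methoxyphenyl, or a phenyl carrying an amine or a carboxylic acid, would read at this carbon, and whether any group here can give a lower number than compound 3.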